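The source may report more compounds than this note shows. Statements on the series, on what has been measured and on what is new or still open speak of the compounds shown alone.

Measured so far:
compound 1, `COCC(=N)NCCCCN` — 42%
compound 2, `COCCCC(=N)NCCCCN` — 15%

Among the compounds with values here, in an assay on isolated protein for inhibition of Nitric oxide synthase, inducible (Homo sapiens), read by spectrophotometry, using NADPH, tested at 1 mM, in the presence of a further agent that is not named here (a higher number here means more inhibition at the concentration tested (going by the name of the read-out), a lower number less inhibition), compound 2 stands lowest of the two numbers; the nearest is compound 1, and the one step, a number 27 percentage points lower from compound 1 to compound 2 (beyond the scatter), was modest. Compound 3, `C=CCC(=N)NCCCCN`, differs from compound 2 by vinyl in place of 2-methoxyethyl on a saturated chain carbon bound to a carbon with a double bond to nitrogen. Within the data shown here, the only step that bears on it is that from compound 1 to compound 2, where a longer chain went with less inhibition; compound 3 returns to a group of the size of compound 1's, so an upward step in this assay is expected, a number 20 percentage points higher from compound 2 to compound 3 (beyond the scatter). Compound 3 is therefore estimated at 35%, in the range 10% to 60%.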

Compound 3, a percentage reported as inhibition, at one concentration (the size of the read-out at that concentration, not a potency): 100%
The estimate for compound 3 lay 65 percentage points below the measured number; measured number above the stated range.
By their numbers in this assay, from the lowest: compound 2; then compound 1; then compound 3.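

In this assay, the group on a saturated chain carbon bound to a carbon with a double bond to nitrogen can move the number upward as well as downward: vinyl gives a number 85 percentage points higher from compound 2 to compound 3 (beyond the scatter) and a number 58 percentage points higher from compound 1 to compound 3 (beyond the scatter). Compound 1 and compound 2 alone showed only a loss with the longer group, whereas the step to vinyl shows that the kind of group here matters, not only its length. Nothing measured here accounts for the size of these steps.

As far as these compounds go, whether the double bond itself is needed remains open, and an ethyl group at this place would bear on that. An amine or a longer chain ending in a double bond is equally unplaced in this series.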